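The compounds below may be only part of what the source reports. "The series", "measured", "known", "first", "only" and "open" are said of these compounds alone.

The study follows three measured compounds that share one core and differ only in the group on one aromatic carbon. Compound 1 `COCCOc1nc(N)nc2c1ncn2/C=C1/CC1(CO)CO` carries a 2-methoxyethoxy group there, compound 2 `CN(C)c1nc(N)nc2c1ncn2/C=C1/CC1(CO)CO` a dimethylamino group, and compound 3 `CC(C)Nc1nc(N)nc2c1ncn2/C=C1/CC1(CO)CO` an isopropylamino group. In an ADME assay on HFF cells (Homo sapiens) for cytotoxicity, with a stated time of 8 days (a lower number here means that less compound is tolerated, a higher number that more compound is tolerated), compound 1 gives > 300000 nM, which is a limit of the assay rather than a number. In this assay compound 2 likewise gives > 300000 nM, again a limit. In this assay compound 3 gives > 300000 nM, also a limit. Where compound 3 stands can thus only be stated as a limit, and the same holds for its two neighbours, all three sitting at the limit of > 300000 nM in this assay, at which 3 of the 3 values shown sit. The steps a step that the two limits leave unreadable from compound 1 to compound 2, a step that the two limits leave unreadable from compound 1 to compound 3 and a step that the two limits leave unreadable from compound 2 to compound 3 each join two limits and so give no readable size.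

Compound 4 `CCCCNc1nc(N)nc2c1ncn2/C=C1/CC1(CO)CO` differs from compound 3 by butyl in place of isopropyl on a nitrogen on an aromatic ring. Among the measured compounds shown here, no measured step can be read, so no size or direction can be taken from them, and the only guide is that every measured compound sits at the limit. Compound 4 is therefore expected to give about 400000 nM, between 150000 nM and 1500000 nM, most likely reported again as a limit. The expected step is then a step that the limit leaves unreadable from compound 3 to compound 4, within the scatter.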

Compound 4, half-maximal cytotoxic concentration: > 300000 nM
Compound 4: only a limit was reported; the forecaster's own chance of this, stated with the estimate: 85%; the middle value lies beyond the limit too.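

In this assay compound 4 gives > 300000 nM as a limit of the assay, not a number. Among the compounds shown here, no step joining compound 1, compound 2, compound 3 and compound 4 can be read, as all four rest on one limit: the limit of > 300000 nM in this assay, at which 4 of the 4 values shown sit. The compounds shown leave open how much compound is tolerated in this assay and whether these groups differ at all.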